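A few compounds are considered here, and "the series" means these few. Any claim that something is new, unique, unknown or untested is made for them only; others in the source may bear on it.

Measured so far:
- compound 1, `NC(=S)N1CCc2c(OCCCCCOc3ccc(Cl)cc3)cccc21`: > 50000 nM in an ADME assay on Huh-7 cells (Homo sapiens) for cytotoxicity; on this read-out lower numbers stand for higher toxicity in this test and higher numbers for lower toxicity in this test
- compound 2, `O=C(NC(=S)N1CCc2c(OCCCCCOc3ccc(Cl)cc3)cccc21)C1CCCCC1`: > 50000 nM in this assay

Both values are limits of this assay, not numbers. Compound 2 therefore stands at the limit of > 50000 nM in this assay, at which 2 of the 2 values shown sit. Among the measured compounds shown here, the only measured step, a step that the two limits leave unreadable from compound 1 to compound 2, is unreadable, since both ends are limits. Compound 3, `O=C(NC(=S)N1CCc2c(OCCCCCOc3ccc(Cl)cc3)cccc21)c1cccs1`, is not yet measured in this assay. The change from compound 2 to compound 3 is thiophen-2-yl in place of cyclohexyl on a carbonyl carbon. For the measured compounds named here, no measured step bears on this change; the single measured step, a step that the two limits leave unreadable from compound 1 to compound 2, gives no size at all. With compound 2 at the limit and no readable step anywhere in the series, the expectation for compound 3 rests on that limit alone, and no shift beyond the scatter is expected in this assay. Compound 3 is therefore estimated at 60000 nM, with a range from 25000 nM to 150000 nM. The step this estimate implies, a step that the limit leaves unreadable from compound 2 to compound 3, is expected to stay within the scatter, and a further limit rather than a number is the more likely outcome.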

Compound 3, half-maximal cytotoxic concentration: 10700 nM
Compound 3: the middle estimate sits 5.6-fold (0.75 log units) above what was measured; the whole stated range lies above it.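

At the carbonyl carbon on the amide-type nitrogen, the ring carried there matters in this assay: thiophen-2-yl in place of cyclohexyl gives an at least 4.6-fold lower number from compound 2 to compound 3 (0.66 log units; beyond the scatter). Set against the unsubstituted thiourea-type nitrogen of compound 1, (thiophen-2-yl)carbonyl in place of hydrogen gives an at least 4.6-fold lower number from compound 1 to compound 3 (0.66 log units; beyond the scatter), while the step from compound 1 to the cyclohexylcarbonyl of compound 2 cannot be read. Compound 2 carries a carbonyl at this place and still stands at a limit of the assay, so a carbonyl alone does not bring the read-out to a number: the limit of > 50000 nM in this assay, at which 2 of the 3 values shown sit.

Going by these compounds, whether the lower number follows the sulfur or the aromatic ring as such stays open; phenyl or furan-2-yl on the same carbonyl would separate the two. The compounds shown also leave open how a small acetyl group or a basic aminoalkyl carbonyl group would read at this nitrogen.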